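Chloro next to the ring nitrogen in phenylpropanoic acid alkynes

The source may hold more compounds than are shown below. What is called first, only, known or untested is meant among the compounds shown, and "the series" means these compounds.

Three compounds were measured in an in vitro functional assay on 1321-N1 cells for agonist activity at Free fatty acid receptor 1 (Homo sapiens), read by fluorescence, spectrophotometry and calcium flux; on this read-out higher numbers stand for larger maximal responses and lower numbers for smaller maximal responses. Compound 1 `O=C(O)CCc1ccc(C#Cc2ccnc(Cl)c2)cc1` gives 94%, compound 2 `O=C(O)CCc1ccc(C#Cc2cccnc2)cc1` gives 96%, and compound 3 `O=C(O)CCc1ccc(C#Cc2cc(Cl)nc(Cl)c2)cc1` gives 103%. The difference between the cores of compound 1 and compound 2 is not broken down here. From compound 1 to compound 3 the change is chloro in place of hydrogen on an aromatic carbon, and this step is a number 9 percentage points higher from compound 1 to compound 3 (within the scatter). Compound 4 `O=C(O)CCc1ccc(C#Cc2cccnc2Cl)cc1` is not yet measured; it arises from compound 2 by the same kind of change, (chloro in place of hydrogen on an aromatic carbon), though here the new chloro sits ortho to a large group rather than meta to a chloro group and meta to a large group. Resting on compound 2 with 96% and on the step of a number 9 percentage points higher from compound 1 to compound 3 (within the scatter), the step to compound 4 is expected to be a number 4 percentage points higher from compound 2 to compound 4 (within the scatter). Compound 4 is therefore estimated to give 100% in this assay, expected between 86% and 112%.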

Compound 4, largest response reached (reported as efficacy), in percent of the reference or control that the assay uses: 91%
Compound 4: the middle estimate sits 9 percentage points above what was measured; low and high end bracket the measured number.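

In this assay, chloro in place of hydrogen next to the ring nitrogen gives a number 5 percentage points lower from compound 2 to compound 4 (within the scatter). Set beside the earlier step, the same change does not read differently on the two cores: the same change on two cores in this assay, a number 9 percentage points higher (within the scatter) from compound 1 to compound 3 and a number 5 percentage points lower (within the scatter) from compound 2 to compound 4, 14 percentage points apart, within the scatter of two such steps. This shows that, for the maximal response on these two cores, the change carries over without a difference that can be told from the scatter, but it does not show that chloro raises or lowers the response on either core, or that its place matters.

The compounds shown leave open whether a larger change would separate the cores. A methoxy group or an amine on that aromatic carbon, for instance, might or might not leave the maximal response where it stands.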